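Tolerance notes: phenyl for tert-butyl, compound 1 to compound 3

The source may report more compounds than this note shows. Statements on the series, on what has been measured and on what is new or still open speak of the compounds shown alone.

compound 1, `Cc1ccc2[nH]c(=O)c(CN(Cc3ccc(F)cc3)Cc3ccc(C(C)(C)C)cc3)cc2c1`: > 27000 nM (a limit of the assay)
compound 2, `CC(C)c1ccc2[nH]c(=O)c(CN(Cc3ccc(F)cc3)Cc3ccc(C(C)(C)C)cc3)cc2c1`: 7900 nM

In a toxicity assay on MDCK cells (Canis lupus familiaris) for cytotoxicity, read by crystal violet staining, with a stated time of 48 h (a higher number here means that more compound is tolerated, a lower number that less compound is tolerated), compound 1 gives > 27000 nM, which is a limit of the assay and not a number, so compound 1 stands only at the edge marked by the limit of > 27000 nM in this assay, at which 1 of the 2 values shown sits. Compound 2 gives 7900 nM. Going by the values given here, the only measured step is an at least 3.4-fold lower number from compound 1 to compound 2 (0.53 log units; beyond the scatter), a change on the ring of the shared core. Compound 3 `Cc1ccc2[nH]c(=O)c(CN(Cc3ccc(F)cc3)Cc3ccc(-c4ccccc4)cc3)cc2c1` is not yet measured; it differs from compound 1 by phenyl in place of tert-butyl on an aromatic carbon of a six-membered aromatic ring of carbon only. The measured step concerns a different ring and a different pair of groups, so it bears on the present change only loosely. The expected step is an at least 1.5-fold lower number from compound 1 to compound 3 (0.17 log units; that floor lies within the scatter), small and toward a lower tolerated concentration, staying near the limit. Compound 3 is estimated at 18000 nM, between 7000 nM and 40000 nM.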

Compound 3, half-maximal cytotoxic concentration: > 5000 nM
Compound 3: no number, only a limit; the forecaster's own chance of this, stated with the estimate: 40%; the middle value does not contradict the limit.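

Compound 1 and compound 3 each carry only a limit of the assay and not a number, so the step between them cannot be read. Going by these compounds, whether phenyl in place of tert-butyl changes the tolerated concentration, and in which direction, stays open.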